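Swapping the amide-bound benzyl group in a lipophilicity series

The source may hold more compounds than are shown below. What is called first, only, known or untested is meant among the compounds shown, and "the series" means these compounds.

Measured compounds:
Compound 1, `Cc1ccsc1C(=CCCN(C)C(CO)C(=O)NCc1ccc(Cl)cc1)c1sccc1C`: 6.47
Compound 2, `Cc1ccsc1C(=CCCN(C)C(CCN)C(=O)NCc1ccc(Cl)cc1)c1sccc1C`: 5.85
Compound 3, `Cc1ccsc1C(=CCCN(C)C(CCO)C(=O)NCc1ccc(Cl)cc1)c1sccc1C`: 6.38

These three compounds share a core and differ only on a saturated chain carbon. In a physicochemical assay for lipophilicity, read by HPLC (on this read-out lower numbers stand for lower lipophilicity and higher numbers for higher lipophilicity), compound 1 gives 6.47, compound 2 gives 5.85 and compound 3 gives 6.38. Compound 3 stands second highest of the three; its nearest neighbour is compound 1, with a number 0.09 log units lower from compound 1 to compound 3 (within the scatter), and its furthest is compound 2, with a number 0.53 log units higher from compound 2 to compound 3 (beyond the scatter).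

Compound 4, `Cc1ccsc1C(=CCCN(C)C(CCO)C(=O)NC(C)c1ccccc1)c1sccc1C`, has not yet been measured. It differs from compound 3 at a different place: 1-phenylethyl in place of 4-chlorobenzyl on an amide-type nitrogen. For the measured compounds named here, none of the measured steps touches the amide-type nitrogen; all three, a number 0.62 log units lower from compound 1 to compound 2 (beyond the scatter), a number 0.09 log units lower from compound 1 to compound 3 (within the scatter) and a number 0.53 log units higher from compound 2 to compound 3 (beyond the scatter), concern the chain carbon alone, so there is no direct precedent for this change within the set. The exchange keeps the count of heavy atoms, donors, acceptors and charge unchanged, which leaves little reason to expect a large shift; a small step is estimated, a number 0.18 log units lower from compound 3 to compound 4 (within the scatter). Compound 4 is therefore expected to come out near 6.2, within a range from 5.8 to 6.6.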

Compound 4, partition coefficient: 6.1
Beside the measured number, compound 4's estimate is 0.10 log units above it; measured number inside the range.
By their numbers in this assay, from the lowest: compounds 2, 4, 3 and 1 (each within the scatter of the next, the first and the last beyond it).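

In this assay, the exchange of 4-chlorobenzyl for 1-phenylethyl on an amide-type nitrogen gives a number 0.28 log units lower from compound 3 to compound 4 (within the scatter), the only step shown at this nitrogen, whereas the earlier steps all concerned the saturated chain carbon. So this particular exchange, in which the leaving and entering groups have the same count of heavy atoms, the same six-membered aromatic ring of carbon only, no hydrogen-bond donors or acceptors and no net charge, and in which chlorine gives way to carbon, cannot be told apart from repeated measurement of a single compound. Nothing available accounts for this result.

The exchange removes the chlorine and rearranges the carbons in one step, so the compounds shown leave open what each of these contributes; an unsubstituted benzyl group on the same nitrogen would separate the two. Also open, from the compounds shown here alone, are whether a group of a different kind there, such as a carboxylic acid or an amine on the aromatic ring, would shift the reading further, and whether the same exchange reads alike with the amino-bearing chain of compound 2.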